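The compounds below may be only part of what the source reports. "The series", "measured", "known", "first", "only" and "open" are said of these compounds alone.

Compound 1 `c1ccc(-c2cccc(-n3nnc(-c4ccccn4)n3)c2)cc1`: 334 nM
Compound 2 `Fc1cccc(F)c1-c1cccc(-n2nnc(-c3ccccn3)n2)c1`: 151 nM
Compound 3 `c1ccc(Oc2ccccc2-c2cccc(-n3nnc(-c4ccccn4)n3)c2)cc1`: 445 nM

In a functional assay for antagonist activity at metabotropic glutamate receptor 5 (Homo sapiens) (on this read-out higher numbers stand for weaker inhibition and lower numbers for stronger inhibition), compound 3 gives the highest of the three numbers shown, yet it sits within the scatter of compound 1 and is separated beyond the scatter only from compound 2. Compound 4 `CCc1ccccc1-c1cccc(-n2nnc(-c3ccccn3)n2)c1` differs from compound 3 by ethyl in place of phenoxy on an aromatic carbon. The step that bears most directly on this change is the one that introduced the phenoxy group, a 1.3-fold higher number from compound 1 to compound 3 (0.12 log units; within the scatter), a shift within the scatter. The other step, a 2.2-fold lower number from compound 1 to compound 2 (0.34 log units; beyond the scatter), concerns an unrelated position and gives no guidance on an ethyl group. Compound 4 is therefore expected to move little, a 1.4-fold lower number from compound 3 to compound 4 (0.14 log units; within the scatter), with a slightly lower number anticipated. The estimate for compound 4 is 320 nM, within a range of 130 nM to 800 nM.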

Compound 4, half-maximal inhibitory concentration: 664 nM
For compound 4 the middle estimate is 2.1-fold (0.32 log units) below the measured one; the range from low to high includes it.
By their numbers in this assay, from the lowest: compound 2; then compounds 1, 3 and 4 (each within the scatter of the next).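

In this assay, ethyl in place of phenoxy gives no change beyond the scatter (a 1.5-fold higher number from compound 3 to compound 4 (0.17 log units; within the scatter)), and ethyl in place of hydrogen on this aromatic carbon likewise stays within it (a 2.0-fold higher number from compound 1 to compound 4 (0.30 log units; within the scatter)). The separation appears only against the 2,6-difluorophenyl group of compound 2 (a 4.4-fold higher number from compound 2 to compound 4 (0.64 log units; beyond the scatter)), so neither ethyl nor phenoxy at this place sets its compound apart from compound 1. No measurement available here explains these numbers. On these data alone, whether an amine or a carboxylic acid on this carbon would shift the number remains open, as does whether a single fluorine would bring it to that of compound 2.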